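Two Analogues at the Limit and a Methoxy Swap

The source may hold more compounds than are shown below. What is called first, only, known or untested is meant among the compounds shown, and "the series" means these compounds.

Compound 1 `Cc1ccc(Cl)cc1-n1nncc1CN1C(=O)C2(C(C#N)=C(N)Oc3c2c2nc4ccccc4nc2c2ccccc32)c2ccccc21` was tested in an ADME assay on HUVEC cells (Homo sapiens) for antiproliferative activity, read by MTT assay, with a stated time of 48 h; a lower number here means a stronger inhibitor, a higher number a weaker inhibitor. In this assay compound 1 gives > 50000 nM, which is a limit of the assay rather than a number. Compound 2 `CCOc1ccccc1-n1nncc1CN1C(=O)C2(C(C#N)=C(N)Oc3c(N)cc4nc5ccccc5nc4c32)c2ccccc21` shares the same core and differs in its outer parts. In this assay compound 2 gives > 50000 nM, again only a limit and not a measured number. Compound 2 therefore stands exactly where the other value stands: both sit at the limit of > 50000 nM in this assay, at which 2 of the 2 values shown sit, and nothing beyond that limit is known about either compound. Compound 3 `COc1ccc(OC)c(-n2nncc2CN2C(=O)C3(C(C#N)=C(N)Oc4c(N)cc5nc6ccccc6nc5c43)c3ccccc32)c1` is the next compound to be measured in this assay. It differs from compound 2 in one place: 2,5-dimethoxyphenyl in place of 2-ethoxyphenyl on an aromatic nitrogen. Within the data shown here, no step between measured compounds is available, so the size of this change cannot be read from any measured pair. Because both values shown sit at the limit of > 50000 nM in this assay, at which 2 of the 2 values shown sit, the step that the limit leaves unreadable from compound 2 to compound 3 is expected to be none beyond the scatter. Compound 3 is accordingly estimated at 60000 nM, with a range from 20000 nM to 200000 nM, and is most likely to be reported as a limit once more.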

Compound 3, half-maximal inhibitory concentration: > 50000 nM
Compound 3: only a limit was reported; the forecaster's own chance of this, stated with the estimate: 85%; the middle value does not contradict the limit.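

No step can be read from compound 2 to compound 3, because both results are limits of the assay and not numbers: the limit of > 50000 nM in this assay, at which 3 of the 3 values shown sit.

The compounds shown leave open what real values compound 1, compound 2 and compound 3 have in this assay, and whether 2,5-dimethoxyphenyl in place of 2-ethoxyphenyl makes any difference there.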